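This account rests on a few compounds, and the source may have more. Where it says the series, first, only, none or still open, it means among the compounds named here.

Series notes. Compound 1 `COc1ccccc1C(=O)Nc1cccc(NC(=O)c2cccc(F)c2)c1` carries two amides on a shared core; in an in vitro functional assay on HEK293-A cells for antagonist activity at metabotropic glutamate receptor 5 (Rattus norvegicus), read by calcium flux (on this read-out higher numbers stand for weaker inhibition and lower numbers for stronger inhibition), compound 1 gives 6480 nM. Compound 2 `COc1ccccc1C(=O)Nc1cccc(NC(=O)c2cccc(C#N)c2)c1` differs only at one aryl, and in this assay compound 2 gives 1800 nM. Among the compounds with values here, compound 1 thus stands at the highest of the two numbers measured, the weaker inhibitor, and the only step recorded runs a 3.6-fold lower number from compound 1 to compound 2 (0.56 log units; beyond the scatter), a change of cyano in place of fluoro on an aromatic carbon.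

Compound 3 `O=C(Nc1cccc(NC(=O)c2cccc(Cl)c2)c1)c1cccc(F)c1` changes the other amide: 3-chlorophenyl in place of 2-methoxyphenyl on a carbonyl carbon. Within the data shown here, no measured step touches this position, so the one recorded step gives only a sense of scale, not direction. The expectation for compound 3 is therefore set near compound 1, with a step of a 1.3-fold lower number from compound 1 to compound 3 (0.11 log units; within the scatter) treated as uncertain in sign. Compound 3 is estimated at 5000 nM in this assay, expected between 1500 nM and 16000 nM.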

Compound 3, half-maximal inhibitory concentration: > 30000 nM
Compound 3: a limit, no number; the forecaster's own chance of this, stated with the estimate: 20%; at least 6.0-fold (0.77 log units) between middle value and limit.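

At this carbonyl carbon the series is not indifferent to the aryl group: 3-chlorophenyl in place of 2-methoxyphenyl gives an at least 4.6-fold higher number from compound 1 to compound 3 (0.66 log units; beyond the scatter), so the number moves upward, whereas the earlier step at the other aryl lowered it. In this assay compound 3 reads > 30000 nM, which is a limit of the assay and not a number. The step therefore fixes a direction but only a minimum size, and the true distance stays unknown because the reading ends at a limit: the limit of > 30000 nM in this assay, at which 1 of the 3 values shown sits.

The compounds shown do not separate the loss of 2-methoxyphenyl from the arrival of 3-chlorophenyl. As far as these compounds go, an unsubstituted phenyl, a pyridine or a chain bearing an amine on this carbonyl carbon would bear on that question, and whether any of them keeps inhibition remains open.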